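Cyclopentyl for isopropyl on the amide of compound 2

This account rests on a few compounds, and the source may have more. Where it says the series, first, only, none or still open, it means among the compounds named here.

Two compounds of this series have numbers in a functional assay on HeLa cells (Homo sapiens) for antiproliferative activity, read by CCK-8 assay, with a stated time of 72 h; a lower number here means a stronger inhibitor of growth, a higher number a weaker inhibitor of growth. Compound 1, with the structure `CCC1C(=O)N(C)c2cnc(-n3ccc4cc(C(=O)NCC(C)C)ccc43)nc2N1c1ccn(C)n1`, gives 4970 nM in this assay. Compound 2, with the structure `CC[C@@H]1C(=O)N(C)c2cnc(-n3ccc4cc(C(=O)NC(C)C)ccc43)nc2N1C1CCCC1`, gives 292 nM in this assay. Compound 2 thus holds the lower of the two numbers, and its separation from compound 1 lies beyond the scatter of repeated measurements. Among the compounds with values here, the two compounds differ in more than one place, so no single structural step between them can be read from their values; they show only that compound 2 is the stronger of the pair.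

Compound 3, with the structure `CC[C@@H]1C(=O)N(C)c2cnc(-n3ccc4cc(C(=O)NC5CCCC5)ccc43)nc2N1C1CCCC1`, has not yet been measured in this assay. It differs from compound 2 in one place: cyclopentyl in place of isopropyl on an amide-type nitrogen. Within the data shown here, no measured pair in this set isolates a change of this kind, so there is no step to lean on. The change is small and keeps the amide-type nitrogen and its carbonyl neighbour as they are. Compound 3 is therefore expected to fall close to compound 2, with a step of a 1.3-fold lower number from compound 2 to compound 3 (0.12 log units; within the scatter) that need not exceed the scatter. The estimate for compound 3 in this assay is 220 nM, within the range 70 nM to 700 nM.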

Compound 3, concentration for 50% growth inhibition: 247 nM
The estimate for compound 3 lay 1.1-fold (0.05 log units) below the measured number, within the range that was stated.
By their numbers in this assay, from the lowest: compounds 3 and 2 (each within the scatter of the next); then compound 1.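

In this assay, within the data shown here, this is the first pair that differs in one place, and it gives a 1.2-fold lower number from compound 2 to compound 3 (0.07 log units; within the scatter) for cyclopentyl in place of isopropyl on the amide-type nitrogen. Among these compounds, on these numbers the two compounds cannot be told apart, so this position takes a five-membered carbon ring in place of the open isopropyl group with no change that can be distinguished from the scatter, something that the gap between compound 1 and compound 2 could never show, as no single step to compound 1 can be read. The result is a single step on one core and one cell line, and nothing in the data bears on why the number stays level.

The compounds shown leave open how this position responds to groups of another kind on the same nitrogen, such as a phenyl ring, a longer chain, or a chain ending in an amine or a carboxylic acid. They also leave open whether the exchange of isopropyl for cyclopentyl would read the same if the other groups on the shared core were different.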